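Removing a Ring Nitrogen Methyl and Cytotoxicity on Hamster Cells

The source may hold more compounds than are shown below. What is called first, only, known or untested is meant among the compounds shown, and "the series" means these compounds.

Compound 1, `C[C@@H]1CN(c2nccc3[nH]c(-c4ccc(F)c(F)c4)nc23)C[C@H](C)N1`, gives 6500 nM in an ADME assay on CHO cells (Cricetulus griseus) for cytotoxicity, read by MTT assay; on this read-out lower numbers stand for higher toxicity in this test and higher numbers for lower toxicity in this test.
Compound 2, `C[C@@H]1CN(c2nccc3[nH]c(-c4ccc(F)c(F)c4)nc23)C[C@H](C)N1C`, gives a value that is a limit of the assay, > 50000 nM.
Compound 3, `CN1CCN(C2CCN(c3nccc4[nH]c(-c5ccc(F)c(C(F)(F)F)c5)nc34)CC2)CC1`, gives 4800 nM.

Compound 1 and compound 2 share one core and differ in one place: hydrogen in place of methyl on an amine nitrogen in a ring. That change produced an at least 7.6-fold lower number from compound 2 to compound 1 (0.88 log units; beyond the scatter). The step is reported only as a lower bound because compound 2 sits at the limit of > 50000 nM in this assay, at which 1 of the 3 values shown sits.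

Compound 3 carries a different core; the difference between the two cores is not broken down here. In this assay compound 3 and compound 1 lie within the scatter of each other, so no order between them can be read.

Compound 4, `Fc1ccc(-c2nc3c(N4CCC(N5CCNCC5)CC4)nccc3[nH]2)cc1C(F)(F)F`, has not been measured. It differs from compound 3 by hydrogen in place of methyl on an amine nitrogen in a ring, the same kind of change as that from compound 2 to compound 1, though around the place it is not the same: in compound 2 the ring nitrogen is next to two ring atoms that each bear a methyl group, whereas in compound 3 no such neighbouring methyl groups are present.

On the strength of the step from compound 2 to compound 1 alone, a lower number is expected for compound 4 than for compound 3, estimated as a 3.2-fold lower number from compound 3 to compound 4 (0.51 log units; beyond the scatter). Compound 4 is therefore expected to give about 1500 nM in this assay, with a plausible range from 400 nM to 5000 nM.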

Compound 4, half-maximal cytotoxic concentration in the CHO assay: 34000 nM
Beside the measured number, compound 4's estimate is 23-fold (1.36 log units) below it; the measured number lies above the stated range.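

In the CHO assay, hydrogen in place of methyl on the ring amine nitrogen gave a 7.1-fold higher number from compound 3 to compound 4 (0.85 log units; beyond the scatter) and so the same change ran in opposite directions on the two cores: the same change on two cores in the CHO assay, an at least 7.6-fold lower number (0.88 log units; beyond the scatter) from compound 2 to compound 1 and a 7.1-fold higher number (0.85 log units; beyond the scatter) from compound 3 to compound 4, at least 54-fold (1.73 log units) apart, beyond the scatter of two such steps. In the CHO assay compound 2 gives > 50000 nM as a limit of the assay and not a number. The earlier step is therefore known only as a bound: the limit of > 50000 nM in the CHO assay, at which 1 of the 4 values shown sits. The result shows that the direction of this change in cytotoxicity did not carry from the core of compound 1 to the core of compound 3, but two pairs give no rule for the series and do not show which of the differences between the two cores or around the changed nitrogen decides the direction. In a physicochemical assay for solubility, read by HPLC, using the shake flask method, in phosphate buffer, with a stated time of 20 h, at pH 6.5 (a lower number here means a less soluble compound, a higher number a more soluble compound), compound 3 gives 195000 nM and compound 4 gives 200000 nM and these two values lie within the scatter of each other, so no order between them can be read.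

The compounds shown leave open how the cytotoxicity read-out responds when a longer chain such as ethyl, or an acetyl group, stands on that ring nitrogen in place of methyl. They also leave open which direction the change from 4-methylpiperazin-1-yl to piperazin-1-yl takes on any core beyond that of compound 3.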